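The source may report more compounds than this note shows. Statements on the series, on what has been measured and on what is new or still open speak of the compounds shown alone.

Measured so far:
compound 1 `NS(=O)(=O)Oc1ccc2c(c1)CN(C(=O)c1cccc(N3CCC(N4CCCCC4)CC3)c1)CC2` — 0%
compound 2 `NS(=O)(=O)Oc1ccc2c(c1)CN(C(=O)c1cccc(N3CCN(c4ncccn4)CC3)c1)CC2` — 1.6%

In an assay on HEK293 cells for inhibition of Steryl-sulfatase (Homo sapiens), tested at 0.1 uM (on this read-out lower numbers stand for a weaker effect and higher numbers for a stronger effect at the one concentration tested), compound 1 gives 0%, and compound 2 gives 1.6%; the two numbers lie within the usual scatter of each other, so neither can be set apart from the other. Among the compounds with values here, no step between measured compounds that differ in one place is at hand. Compound 3 `NS(=O)(=O)Oc1ccc2c(c1)CN(C(=O)c1cccc(N3CCC(Cc4ccccc4)CC3)c1)CC2` differs from compound 1 by benzyl in place of piperidin-1-yl on a saturated ring carbon. On the numbers shown, both of which sit close to no effect, no step beyond the scatter is expected, and a number 3 percentage points higher from compound 1 to compound 3 (within the scatter) is the expected change. Compound 3 is expected to give 3%, with a range from 0% to 15%.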

Compound 3, a percentage reported as inhibition, at one concentration (the size of the read-out at that concentration, not a potency): 1.4%
Compound 3: middle estimate off by 1.6 percentage points, on the high side, within the range that was stated.
By their numbers in this assay, from the lowest: compounds 1, 3 and 2 (each within the scatter of the next).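

In this assay, benzyl in place of piperidin-1-yl on a saturated ring carbon gives a number 1.4 percentage points higher from compound 1 to compound 3 (within the scatter), so exchanging a non-aromatic ring with one nitrogen for an aromatic ring of carbon only does not set the two compounds apart at this position. Both numbers lie close to no effect, which leaves little room to read this position. Nothing at hand gives a reason for this result. On these data alone, it remains open whether another group on this ring carbon, such as a carboxylic acid, a primary amine or a longer alkyl chain, would give a stronger effect in this assay.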